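Swapping cyclohexyl for methyl on a fused core

This account rests on a few compounds, and the source may have more. Where it says the series, first, only, none or still open, it means among the compounds named here.

Of the compounds shown here, three with a shared hydroxylated core have been measured in an assay on isolated protein for inhibition of CCR4-NOT transcription complex subunit 7 (Homo sapiens), read by fluorescence; on this read-out lower numbers stand for stronger inhibition and higher numbers for weaker inhibition. Compound 1 `O=c1[nH]c2ncsc2c(=O)n1O` gives 28700 nM, compound 2 `O=c1[nH]c2ncn(C3CCCCC3)c2c(=O)n1O` gives 28200 nM, and compound 3 `CCCCOCCCn1cnc2[nH]c(=O)n(O)c(=O)c21` gives 20600 nM. Compound 2 sits second highest of the three numbers; its nearest neighbour is compound 1, whose value differs from it by an amount that lies within the usual scatter, and even the furthest value, that of compound 3, is separated from compound 2 by a gap that also stays within the scatter. The three compounds therefore read as essentially alike in this assay.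

Compound 4 `Cn1cnc2[nH]c(=O)n(O)c(=O)c21` has not yet been measured. It is derived from compound 2 by the change (methyl in place of cyclohexyl on an aromatic nitrogen), in words methyl in place of cyclohexyl on an aromatic nitrogen. For the measured compounds named here, no step between two measured compounds at this position has been recorded, so there is nothing to calibrate the change against; the only guide is that the three measured compounds, which differ widely in what sits on this ring, give values that do not separate beyond the scatter.

The step from compound 2 to compound 4 is therefore expected to be small, a 1.1-fold higher number from compound 2 to compound 4 (0.03 log units; within the scatter), with no direction beyond the scatter. Compound 4 is estimated at 30000 nM, within a range from 15000 nM to 60000 nM.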

Compound 4, half-maximal inhibitory concentration: 251000 nM
The estimate for compound 4 lay 8.4-fold (0.92 log units) below the measured number; measured number above the stated range.
By their numbers in this assay, from the lowest: compounds 3, 2 and 1 (each within the scatter of the next); then compound 4.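

In this assay, for the compounds shown here, methyl in place of cyclohexyl on an aromatic nitrogen gives an 8.9-fold higher number from compound 2 to compound 4 (0.95 log units; beyond the scatter), so this position is not indifferent to what it carries, which the earlier compounds could not show because their values never separated beyond the scatter. The cyclohexyl of compound 2 and the butoxypropyl chain of compound 3 sit on this same nitrogen and read alike despite their different shapes, whereas the single carbon of the methyl sets compound 4 apart: compound 4 gives 251000 nM where compound 3 gives 20600 nM. Nothing shown here bears on what lies behind this step.

From the compounds shown here alone, it remains open how large the group on this nitrogen must be before the number returns to that of compound 2, a question that ethyl, isopropyl or a linear propyl would narrow, and whether a bare hydrogen there would read like methyl. Also open, going by these compounds, is whether an amine or a carboxylic acid at the end of a longer chain would read like the butoxypropyl chain of compound 3.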